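The compounds below may be only part of what the source reports. "The series", "measured", "known", "first", "only" and "open" are said of these compounds alone.

Compound 3 `Cc1ccc2nc(/N=C3\C(=O)N(CN(c4ccccc4)c4ccccc4)c4cccc(Cl)c43)sc2c1` stands, in an ADME assay on 184B5 cells (Homo sapiens) for cytotoxicity, read by sulforhodamine B assay, with a stated time of 48 h (a higher number here means a weaker inhibitor of growth, a lower number a stronger inhibitor of growth), at 67800 nM, the second highest of the three numbers in hand. Going by the values given here, its nearest neighbour is compound 2 `Cc1ccc2nc(/N=C3\C(=O)N(CN(c4ccccc4)c4ccccc4)c4cccc(Br)c43)sc2c1`, which gives 70300 nM; the single step there is a 1.0-fold lower number from compound 2 to compound 3 (0.02 log units; within the scatter). Among the compounds with values here, compound 1 `Cc1ccc2nc(/N=C3\C(=O)N(CN4CCCCC4)c4ccccc43)sc2c1` gives 34900 nM and differs from compound 3 in two places at once, so no single step joins the two. Compound 4 `Cc1ccc2nc(/N=C3\C(=O)N(CN(c4ccccc4)c4ccccc4)c4ccccc43)sc2c1` is not yet measured; the change from compound 3 is hydrogen in place of chloro on an aromatic carbon. Only the halogen swap from compound 2 to compound 3 bears on a change at this aromatic carbon, and it fell within the scatter, so the expected step is a 1.1-fold lower number from compound 3 to compound 4 (0.05 log units; within the scatter), none beyond the scatter. Compound 4 is therefore expected near 60000 nM, in the range 30000 nM to 120000 nM.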

Compound 4, concentration for 50% growth inhibition: 27200 nM
Beside the measured number, compound 4's estimate is 2.2-fold (0.34 log units) above it, outside the stated range (below it).
By their numbers in this assay, from the lowest: compounds 4, 1, 3 and 2 (each within the scatter of the next, the first and the last beyond it).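

In this assay the halogen-to-hydrogen change at this aromatic carbon gives a step beyond the scatter, seen as a 2.5-fold lower number from compound 3 to compound 4 (0.40 log units; beyond the scatter) and as a 2.6-fold lower number from compound 2 to compound 4 (0.41 log units; beyond the scatter). The swap between the two halogens stayed within the scatter, so at this position chloro and bromo read alike and hydrogen stands apart from both. No measurement shown here accounts for this step.

Open, from the compounds shown here alone, is whether a fluoro, methyl or methoxy group at this carbon would read with the halogens or with hydrogen. Also open, going by these compounds, is whether the same step appears with the side chain of compound 1.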